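Fluoro for Bromo on an Unmeasured Isoxazole Analogue

The source may hold more compounds than are shown below. What is called first, only, known or untested is meant among the compounds shown, and "the series" means these compounds.

Compound 1: `COc1cccc(-c2cc(COC(Cc3cn(C4CCN(Cc5ccc([N+](=O)[O-])cc5)CC4)nn3)c3ccc(Br)cc3)on2)c1`. In a functional assay on PC-3 cells (Homo sapiens) for cytotoxicity, with a stated time of 48 h (on this read-out higher numbers stand for weaker inhibition and lower numbers for stronger inhibition), compound 1 gives > 25000 nM, which is a limit of the assay and not a number.
Compound 2: `O=[N+]([O-])c1ccc(CN2CCC(n3cc(CC(OCc4cc(-c5ccccc5Br)no4)c4ccc(Br)cc4)nn3)CC2)cc1`. In this assay compound 2 gives > 25000 nM, again a limit of the assay.

Compound 2 therefore stands only at a limit; both values shown sit at the limit of > 25000 nM in this assay, at which 2 of the 2 values shown sit. Among the compounds with values here, the single measured step, a step that the two limits leave unreadable from compound 1 to compound 2, is unreadable for the same reason, so it offers no guide to the size of any change.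

Compound 3 is `O=[N+]([O-])c1ccc(CN2CCC(n3cc(CC(OCc4cc(-c5ccccc5F)no4)c4ccc(Br)cc4)nn3)CC2)cc1`. It differs from compound 2 by fluoro in place of bromo on an aromatic carbon. Within the data shown here, no measured step bears on this change. The step from compound 2 to compound 3 is expected to be a step that the limit leaves unreadable from compound 2 to compound 3, with nothing beyond the scatter that can be claimed. Compound 3 is thus estimated at 40000 nM, within 15000 nM to 150000 nM, and most likely it is expected to be reported as a limit again.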

Compound 3, half-maximal inhibitory concentration: 6000 nM
Beside the measured number, compound 3's estimate is 6.7-fold (0.82 log units) above it; the measured number lies below the stated range.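

Compound 3 is the only one of the three compounds shown to give a number and not a limit of the assay: the limit of > 25000 nM in this assay, at which 2 of the 3 values shown sit. On an aromatic carbon ortho to a large group, fluoro in place of bromo gives an at least 4.1-fold lower number from compound 2 to compound 3 (0.61 log units; beyond the scatter) in this assay, so the halogen at this place can move the read-out, which compounds 1 and 2 could not show. On these data alone, the 2-fluorophenyl group in place of 3-methoxyphenyl gives an at least 4.1-fold lower number from compound 1 to compound 3 (0.61 log units; beyond the scatter), and the full size of both steps stays unknown, as each starts from a limit.

As far as these compounds go, how chloro or methyl at this same place would read in this assay remains open. So does whether fluoro would give a similar step on another carbon of the same ring.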